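This account rests on a few compounds, and the source may have more. Where it says the series, first, only, none or still open, it means among the compounds named here.

Measured compounds:
compound 1 `CCCCCCn1cc(COc2ccc(C(=O)/C=C/c3ccc(Br)cc3)c(O)c2)nn1` — > 100000 nM
compound 2 `C#CCOc1ccc(/C=C/C(=O)c2ccc(OCc3cn(CCCCCC)nn3)cc2O)cc1` — "not determined" (no result reported)

In an ADME assay on cells (Macrophage) for cytotoxicity, read by resazurin assay, with a stated time of 48 h (on this read-out higher numbers stand for lower toxicity in this test and lower numbers for higher toxicity in this test), compound 1 returns only a limit, > 100000 nM. For compound 2 no result is recorded in this assay; the entry reads "not determined" (no result reported). Going by the values given here, compound 2 therefore has no place on the scale of numbers: the one other value present is the limit of > 100000 nM in this assay, at which 1 of the 2 values shown sits, a limit and not a number, so no step between measured compounds can be computed and nothing so far distinguishes one compound from another in this assay.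

Compound 3 `CCCCCCn1cc(COc2ccc(C(=O)/C=C/c3c(F)cccc3Cl)c(O)c2)nn1` has yet to be measured in this assay. Relative to compound 2 the shared core is kept and the change is confined to one place: 2-chloro-6-fluorophenyl in place of 4-(propargyloxy)phenyl on a double-bonded chain carbon bound to a double-bonded chain carbon. Among the compounds with values here, with no measured step available, the size of the step from compound 2 to compound 3 in this assay is expected to be none beyond the scatter, in either direction. Compound 3 is expected to give about 100000 nM in this assay, within 30000 nM to 300000 nM, and a further limit rather than a number is considered the likelier outcome.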

Compound 3, half-maximal cytotoxic concentration: > 100000 nM
Compound 3 ended at the assay's limit; the forecaster's own chance of this, stated with the estimate: 60%; the middle value sits exactly at the limit.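

The step from compound 1 to compound 3 cannot be read, as both compounds stop at a limit in this assay and neither gives a number: the limit of > 100000 nM in this assay, at which 2 of the 3 values shown sit.

The compounds shown leave open whether 2-chloro-6-fluorophenyl and 4-bromophenyl differ at all in half-maximal cytotoxic concentration at this place.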